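Methyl to isopropoxy on the shared core

A few compounds are considered here, and "the series" means these few. Any claim that something is new, unique, unknown or untested is made for them only; others in the source may bear on it.

Measured so far in an assay on cells for inhibition of MAP kinase-interacting serine/threonine-protein kinase 1 (Homo sapiens), read by mobility shift assay, with stated times of 10 min and 60 min, in the presence of a further agent that is not named here; on this read-out lower numbers stand for stronger inhibition and higher numbers for weaker inhibition:
compound 1 `COc1cc(-c2cccnc2)ccc1C(N)=O`, 2800 nM
compound 2 `Cc1cc(-c2cccnc2)ccc1C(N)=O`, 22000 nM

Going by the values given here, compound 2 stands at the higher of the two numbers; its only neighbour is compound 1, and the step of a 7.9-fold higher number from compound 1 to compound 2 (0.90 log units; beyond the scatter) lies beyond the scatter.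

Compound 3 `CC(C)Oc1cc(-c2cccnc2)ccc1C(N)=O` differs from compound 2 in isopropoxy in place of methyl on an aromatic carbon. Among the compounds with values here, the one measured step that bears on this is a 7.9-fold higher number from compound 1 to compound 2 (0.90 log units; beyond the scatter), which runs the other way, from an alkoxy group to methyl. Read backwards, it points to a lower number for compound 3, though isopropoxy is not the methoxy of compound 1, so a somewhat smaller step is expected: a 4.4-fold lower number from compound 2 to compound 3 (0.64 log units; beyond the scatter). Compound 3 is estimated at 5000 nM, within 1500 nM to 16000 nM.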

Compound 3, half-maximal inhibitory concentration: 880 nM
For compound 3 the middle estimate is 5.7-fold (0.75 log units) above the measured one; the whole stated range lies above it.
By their numbers in this assay, from the lowest: compound 3; then compound 1; then compound 2.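

Working from methyl through methoxy to isopropoxy, the position ortho to the carbamoyl group tolerates more than a small alkoxy group in this assay: the gain is large with a 25-fold lower number from compound 2 to compound 3 (1.40 log units; beyond the scatter) and continues beyond methoxy with a 3.2-fold lower number from compound 1 to compound 3 (0.50 log units; beyond the scatter) in the same direction. Among these three compounds, the number falls as the group on this carbon grows, and none goes against that order. No evidence here accounts for these steps.

Still open, going by these compounds, is whether a longer chain such as n-butoxy extends this order or reverses it. An amine such as dimethylamino at this position also remains untested in the compounds shown.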